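The compounds below may be only part of what the source reports. "The series", "measured", "known", "first", "only" and "open" are said of these compounds alone.

Measured so far:

compound 1, `CC(C)(C)OC(=O)/N=C(\NC1=NC(=O)CN1C(C)(C)C)Nc1ccc(Cl)c(Cl)c1`: < 0.167 h
compound 2, `CC(C)N1CC(=O)N=C1NC(=N)Nc1ccc(Cl)c(Cl)c1`: > 1 h
compound 3, `CC(C)n1cc(OC(=O)C(C)(C)C)nc1N/C(=N\C(=O)C(C)(C)C)Nc1ccc(Cl)c(Cl)c1`: > 1 h

In an in vivo ADME assay on the whole organism for metabolic stability, with Homo sapiens as the target, read by LC-MS, at a dose of 160 mg/kg by the oral route (a higher number here means that the compound lasts longer, a lower number that the compound disappears faster), compound 1 gives < 0.167 h, which is a limit of the assay and not a number. Compound 1 therefore stands at the limit of < 0.167 h in this assay, at which 1 of the 3 values shown sits. The two other values stand at the limit of > 1 h in this assay, at which 2 of the 3 values shown sit. Compound 4, `CC(C)N1CC(=O)N=C1N/C(=N\C(=O)OC(C)(C)C)Nc1ccc(Cl)c(Cl)c1`, has not been measured in this assay. It differs from compound 1 by hydrogen in place of methyl on a saturated chain carbon bound to an amine nitrogen in a ring and two saturated chain carbons. For the measured compounds named here, no measured pair shows this change alone, so the step is uncertain. A moderate rise beyond the scatter is expected, as an at least 1.7-fold higher number from compound 1 to compound 4 (0.25 log units; that floor lies within the scatter) shows. Compound 4 is estimated at 0.3 h, in the range 0.1 h to 1.2 h.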

Compound 4, half-life: 0.213 h
For compound 4 the middle estimate is 1.4-fold (0.15 log units) above the measured one; the measured number falls inside the stated range.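

In this assay compound 1 gives < 0.167 h, which is a limit of the assay and not a number. Compound 4 gives a true number, so replacing tert-butyl with isopropyl can be read only as a floor: an at least 1.2-fold higher number from compound 1 to compound 4 (0.10 log units; that floor lies within the scatter). The real step may be larger, but this floor alone does not show a change beyond ordinary repeat variation.

From the compounds shown here alone, how a shorter chain such as ethyl or a small ring such as cyclopropyl would behave at this place remains open. For the compounds shown here, whether the step holds on other compounds also remains open, since only this pair shows it.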